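This account rests on a few compounds, and the source may have more. Where it says the series, first, only, none or still open, it means among the compounds named here.

Measured so far:
compound 1, `C=CCn1c(=N)sc2cc(OC(F)(F)F)ccc21`: 7 mg/kg
compound 2, `N=c1sc2cc(OC(F)(F)F)ccc2n1CC(=O)O`: > 10 mg/kg
compound 3, `N=c1sc2cc(OC(F)(F)F)ccc2n1CCS(N)(=O)=O`: 6 mg/kg

In a functional assay on the whole organism with Rattus norvegicus as the target (a higher number here means that more compound is needed for the effect, a lower number that less compound is needed), compound 1 gives 7 mg/kg. Compound 2 gives > 10 mg/kg, which is a limit of the assay and not a number (the limit of > 10 mg/kg in this assay, at which 1 of the 3 values shown sits). Compound 3 gives 6 mg/kg. Compound 3 and compound 1 therefore sit within the scatter of each other, as a 1.2-fold lower number from compound 1 to compound 3 (0.07 log units; within the scatter) shows, so compound 3 holds no clear lead over compound 1.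

Compound 4, `N=c1sc2cc(OC(F)(F)F)ccc2n1CC[S+]([O-])c1ccccc1`, keeps the shared core and the chain and changes the group on a saturated chain carbon, two bonds along the chain from an aromatic nitrogen: a group of 8 heavy atoms (6 carbon, 1 oxygen, 1 sulfur; one six-membered aromatic ring of carbon only) in place of a group of 4 heavy atoms (1 nitrogen, 2 oxygen, 1 sulfur; no ring), on a saturated chain carbon, two bonds along the chain from an aromatic nitrogen. The measured steps that bear on this all swap the group on that same chain carbon: an at least 1.4-fold higher number from compound 1 to compound 2 (0.15 log units; that floor lies within the scatter), a 1.2-fold lower number from compound 1 to compound 3 (0.07 log units; within the scatter) and an at least 1.6-fold lower number from compound 2 to compound 3 (0.22 log units; that floor lies within the scatter). None of them reached beyond the scatter. The group entering in compound 4 is larger than any tried so far and carries an aromatic ring, so those steps cover it only loosely. The expected step is a 1.2-fold higher number from compound 3 to compound 4 (0.07 log units; within the scatter), with wide uncertainty. Compound 4 is expected to give 7 mg/kg, between 3 mg/kg and 20 mg/kg.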

Compound 4, dose for half-maximal effect: 4.2 mg/kg
For compound 4 the middle estimate is 1.7-fold (0.22 log units) above the measured one; the measured number falls inside the stated range.
By their numbers in this assay, from the lowest: compounds 4, 3 and 1 (each within the scatter of the next). At a limit, above all of these: compound 2.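

The step from sulfamoyl to the larger group in this assay stays small (a 1.4-fold lower number from compound 3 to compound 4 (0.15 log units; within the scatter)). The earlier groups on this saturated chain carbon had no ring, so only compound 4 shows that a six-membered aromatic ring of carbon only, with no hydrogen-bond donor in the entering group, can sit at this place without the number moving beyond the scatter. Nothing measured in this set explains why the number holds within the scatter across so large a swap.

Still open, as far as these compounds go, is whether the aromatic ring or the sulfur and its oxygen matters more, which a benzene ring carried on the chain without the sulfur could help to separate. An amine at this place, or a longer chain leading to the same group, also remains to be seen.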